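Compound 1 as the sole anchor for compound 4

This account rests on a few compounds, and the source may have more. Where it says the series, first, only, none or still open, it means among the compounds named here.

compound 1 `COc1cc(-n2ncnc2-c2ccc(C)cc2)cc(OC)c1OC` gives 300 nM
compound 2 `COc1cc(-c2ncnn2-c2cccc(N)c2)cc(OC)c1OC` gives > 10000 nM as a limit
compound 3 `COc1cc(-c2ncnn2-c2ccc(N)cc2)cc(OC)c1OC` gives > 10000 nM as a limit

Going by the values given here, in a functional assay on Jurkat cells (Homo sapiens) for antiproliferative activity, read by MTT assay, with a stated time of 72 h (a lower number here means a stronger inhibitor, a higher number a weaker inhibitor), compound 1 gives 300 nM as the only true number here. The other two results are limits. Among the compounds with values here, the one measured step is a step that the two limits leave unreadable from compound 2 to compound 3 and so offers no size to carry over. Within the data shown here, compound 4 `COc1cc(-n2ncnc2-c2ccc(Cl)c(Cl)c2)cc(OC)c1OC` differs from compound 1 by 3,4-dichlorophenyl in place of 4-methylphenyl on an aromatic carbon and no measured step covers this change. With compound 1 at 300 nM as the sole anchor, a modest weakening in this assay is expected, though even the direction is a cautious guess. The expected step is a 2.7-fold higher number from compound 1 to compound 4 (0.43 log units; beyond the scatter) as a rough estimate. Compound 4 is estimated at 800 nM with an expected range from 150 nM to 5000 nM on this thin evidence.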

Compound 4, half-maximal inhibitory concentration: > 10000 nM
Compound 4: a limit, no number (the forecaster's own chance of this, stated with the estimate: 15%); at least 12-fold (1.09 log units) between middle value and limit.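

In this assay, going by these compounds alone, the one readable step at this position, on an aromatic carbon between two ring nitrogen atoms, is large: 3,4-dichlorophenyl in place of 4-methylphenyl gives an at least 33-fold higher number from compound 1 to compound 4 (1.52 log units; beyond the scatter). Within the data shown here, this shows that activity depends strongly on what the phenyl ring at this position carries, which the earlier compounds could not show. The result for compound 4 is a limit, not a number: the limit of > 10000 nM in this assay, at which 3 of the 4 values shown sit.

The compounds shown leave open whether a single chlorine, as in 4-chlorophenyl, would keep the activity of compound 1. From the compounds shown here alone, how an unsubstituted phenyl or a 4-methoxyphenyl would behave here also stays open.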